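The compounds below may be only part of what the source reports. "The series", "measured", "known", "first", "only" and "open" are said of these compounds alone.

Measured in a functional assay on MDA-MB-436 cells (Homo sapiens) for antiproliferative activity, read by MTT assay, with a stated time of 24 h; on this read-out lower numbers stand for stronger inhibition and higher numbers for weaker inhibition:
- Compound 1 `O=C(O)CC(NS(=O)(=O)c1cc(F)cc(F)c1)c1ccccc1F`: 89300 nM
- Compound 2 `N#Cc1ccc(S(=O)(=O)NC(CC(=O)O)c2ccc(Cl)cc2Cl)cc1`: 19800 nM

Compound 2 has the lower number of the two, and its gap to compound 1 lies beyond the usual scatter. These two compounds differ in more than one place, so the gap cannot be pinned on any single group.

Compound 3 `O=C(O)CC(NS(=O)(=O)c1cc(F)cc(F)c1)c1ccc(Cl)cc1Cl` differs from compound 2 in one place: 3,5-difluorophenyl in place of 4-cyanophenyl on a sulfonyl sulfur. Among the compounds with values here, no measured pair shows this change alone. Within the data shown here, the only guide is compound 1, which carries the same 3,5-difluorophenyl and gives 89300 nM, so a weaker result in this assay seems more likely than a stronger one. The expected change is modest and toward a higher number: a 1.8-fold higher number from compound 2 to compound 3 (0.25 log units; within the scatter). For compound 3 the estimated value is 35000 nM, with an expected range from 14000 nM to 80000 nM.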

Compound 3, half-maximal inhibitory concentration: 49600 nM
The estimate for compound 3 lay 1.4-fold (0.15 log units) below the measured number, within the range that was stated.
By their numbers in this assay, from the lowest: compound 2; then compounds 3 and 1 (each within the scatter of the next).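

With the 2,4-dichlorophenyl group held fixed, the group on the sulfonyl sulfur can now be judged alone: in this assay, 3,5-difluorophenyl in place of 4-cyanophenyl brings a 2.5-fold higher number from compound 2 to compound 3 (0.40 log units; beyond the scatter) and shows that, for this pair, the swap changes the read-out by more than the usual scatter. Within the data shown here, the other group can also be judged alone for the first time: 2,4-dichlorophenyl in place of 2-fluorophenyl brings a 1.8-fold lower number from compound 1 to compound 3 (0.26 log units; within the scatter) and stays within the scatter, so this pair shows no clear difference. No measurement here explains either result.

Among these compounds, only two groups on the sulfonyl sulfur can be compared, so the effect of a plain phenyl or a 4-methoxyphenyl there remains open. All three compounds also carry a carboxylic acid, leaving open what a primary amide in its place would do.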